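The source may hold more compounds than are shown below. What is called first, only, known or untested is meant among the compounds shown, and "the series" means these compounds.

Measured compounds in a functional assay on A549 cells (Homo sapiens) for antiproliferative activity, read by sulforhodamine B assay, with a stated time of 48 h; on this read-out higher numbers stand for weaker inhibition and lower numbers for stronger inhibition:
compound 1 `COc1cc(OC)c2sc(-c3ccc(N/C=C\C(=O)c4ccc(OC)c(O)c4)cc3)nc2c1` gives 10600 nM; compound 2 `COc1ccc(C(=O)/C=C\Nc2ccc(-c3nc4cc(OC)c(OC)c(OC)c4s3)cc2)cc1O` gives 23000 nM; compound 3 `COc1ccc(C(=O)/C=C\Nc2ccc(-c3nc4cc(OC)c(OC)c(OC)c4s3)cc2)cc1[N+](=O)[O-]` gives 21200 nM.

Compound 4 `COc1cc(C(=O)/C=C\Nc2ccc(-c3nc4cc(OC)c(OC)c(OC)c4s3)cc2)cc([N+](=O)[O-])c1OC` has not yet been measured. It differs from compound 3 by methoxy in place of hydrogen on an aromatic carbon. The difference between the core of compound 3 and the core of compound 1 is not broken down here. From compound 2 to compound 3 the step was a 1.1-fold lower number from compound 2 to compound 3 (0.04 log units; within the scatter).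

The same kind of change, (methoxy in place of hydrogen on an aromatic carbon), made a 2.2-fold higher number from compound 1 to compound 2 (0.34 log units; beyond the scatter). The surroundings are not the same: in compound 2 the place is part of a fused system of two rings, ortho to two methoxy groups and meta and para to a fused ring, while in compound 4 it is ortho to one methoxy group, meta to a large group and meta to a nitro group.

Because a 2.2-fold higher number from compound 1 to compound 2 (0.34 log units; beyond the scatter) was modest, a comparable step is expected, a 1.3-fold higher number from compound 3 to compound 4 (0.12 log units; within the scatter). For compound 4 the estimate in this assay is 28000 nM, expected between 11000 nM and 70000 nM.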

Compound 4, half-maximal inhibitory concentration: 11800 nM
Beside the measured number, compound 4's estimate is 2.4-fold (0.38 log units) above it, and the stated range covers the measured number.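

In this assay, methoxy in place of hydrogen on an aromatic carbon gives a 1.8-fold lower number from compound 3 to compound 4 (0.25 log units; within the scatter). Set beside the earlier use of this change, the step does not carry over from one core to another as a fixed effect: the same change on two cores in this assay, a 2.2-fold higher number (0.34 log units; beyond the scatter) from compound 1 to compound 2 and a 1.8-fold lower number (0.25 log units; within the scatter) from compound 3 to compound 4, 3.9-fold (0.59 log units) apart, beyond the scatter of two such steps. Among these compounds, this does not show what sets the gap, as each core offers only one pair and the two places have different neighbouring groups, so the core and the neighbours cannot be told apart.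

Still open, going by these compounds, is whether an amine or an ethoxy group on the aromatic carbon that takes the methoxy in compound 4 would follow the same course. A further open question is whether the step would hold in other cores.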